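The compounds below may be only part of what the source reports. "The series", "measured", "known", "first", "only" and "open" are said of these compounds alone.

Working notes on the series. For the measured compounds named here, in a functional assay on A549 cells (Homo sapiens) for inhibition, read by CCK-8 assay, with a stated time of 72 h, tested at 8 uM (on this read-out higher numbers stand for more inhibition of growth at the one concentration tested and lower numbers for less inhibition of growth), compound 1 `Nc1ccccc1NC(=O)/C=C/c1ccc(CSc2ccc(Cl)cc2)cc1` gives 59.6% and holds the higher of the two numbers so far. Compound 2 `Nc1ccccc1NC(=O)c1ccc(CSc2ccc(Br)cc2)cc1` gives 45.7% and the gap between the two lies beyond the usual scatter. These two compounds differ in more than one place, so their gap cannot be tied to any single change.

Compound 3 `Nc1ccccc1NC(=O)/C=C/c1ccc(CSc2cccc3ccccc23)cc1` has not yet been measured. Its difference from compound 1 is naphthalen-1-yl in place of 4-chlorophenyl on a sulfur with naphthalen-1-yl in place of 4-chlorophenyl on a sulfur. Going by the values given here, no measured pair tests a change at this place, so the expectation is loose. The expected step of a number 7.6 percentage points lower from compound 1 to compound 3 (within the scatter) is small and downward in this assay and may stay within the scatter. For compound 3 the estimate is 52% with an expected range from 32% to 70% on this read-out.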

Compound 3, percent growth inhibition at one concentration: 71.2%
Beside the measured number, compound 3's estimate is 19.2 percentage points below it, and the stated range ends below it.
By their numbers in this assay, from the lowest: compound 2; then compound 1; then compound 3.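

In this assay, for the compounds shown here, naphthalen-1-yl in place of 4-chlorophenyl on a sulfur gives a number 11.6 percentage points higher from compound 1 to compound 3 (beyond the scatter) and is the first change that can be tied to a single place, which the gap between compound 1 and compound 2 did not allow. It shows that this position, on a sulfur whose other neighbour is a saturated chain carbon, accepts a group with two six-membered aromatic rings in place of one without loss on this read-out. No evidence bearing on the reason for this step is at hand.

Going by these compounds, whether naphthalen-2-yl or a saturated ring such as cyclohexyl on the same sulfur would hold this level remains open. So does whether the same change would carry over to the core of compound 2.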